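The source may report more compounds than this note shows. Statements on the series, on what has been measured and on what is new or still open speak of the compounds shown alone.

Of the compounds shown here, two of a shared core have been measured in a functional assay on A549 cells (Homo sapiens) for antiproliferative activity, read by MTT assay, with a stated time of 48 h; a lower number here means a stronger inhibitor, a higher number a weaker inhibitor. Compound 1, `CN1CCN(CCCOc2c(OCc3ccccc3)cc3oc(-c4ccccc4)cc(=O)c3c2O)CC1`, gives 1300 nM. Compound 2, `COc1cc2oc(-c3ccccc3)cc(=O)c2c(O)c1OCCCN1CCCC1`, gives 6000 nM in this assay. Among these two numbers compound 2 stands highest, and the gap to compound 1, its only neighbour, lies beyond the usual scatter, so compound 2 is the weaker inhibitor of the pair on the numbers shown.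

Compound 3, `COc1cc2oc(-c3ccccc3)cc(=O)c2c(O)c1OCCCN1CCN(C)CC1`, has not yet been measured. It is built from compound 2 by one change: 4-methylpiperazin-1-yl in place of pyrrolidin-1-yl on a saturated chain carbon, three bonds along the chain from an oxygen on an aromatic ring. Among the measured compounds shown here, no step between measured compounds isolates this change, so there is no direct measure of what it does on this core. For the measured compounds named here, the only guide is that compound 1, which also carries the 4-methylpiperazin-1-yl group, gives the lower number, though it differs in a second place as well. On that basis a modest step towards a stronger inhibitor is expected, from compound 2 to compound 3 of a 1.7-fold lower number from compound 2 to compound 3 (0.23 log units; within the scatter) in this assay, though a result within the scatter of compound 2 would not be surprising. Compound 3 is therefore estimated at 3500 nM in this assay, with a range of 1200 nM to 10000 nM.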

Compound 3, half-maximal inhibitory concentration: 18000 nM
The estimate for compound 3 lay 5.1-fold (0.71 log units) below the measured number; measured number outside the range, above it.
By their numbers in this assay, from the lowest: compound 1; then compound 2; then compound 3.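

In this assay, the swap of pyrrolidin-1-yl for 4-methylpiperazin-1-yl on a saturated chain carbon, three bonds along the chain from an oxygen on an aromatic ring, now has a direct measure: a 3.0-fold higher number from compound 2 to compound 3 (0.48 log units; beyond the scatter), so on this core the six-membered ring with two nitrogens gives the weaker inhibitor. Compound 3 also forms a clean pair with compound 1, since both carry 4-methylpiperazin-1-yl, and hydrogen in place of phenyl on a saturated chain carbon bound to an oxygen on an aromatic ring gives a 14-fold higher number from compound 1 to compound 3 (1.14 log units; beyond the scatter), a large loss showing that the lower number of compound 1 goes with its phenyl and not with its amine. No measurement is available that explains either step.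

On these data alone, it remains open whether pyrrolidin-1-yl would also beat 4-methylpiperazin-1-yl on a core carrying that phenyl, since these two amines have been compared only with hydrogen in that place. Also unsettled is how other groups at this place would rank, such as morpholin-4-yl or piperidin-1-yl, or a shorter 2-(pyrrolidin-1-yl)ethyl chain in place of 3-(pyrrolidin-1-yl)propyl.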